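The source may hold more compounds than are shown below. What is called first, only, known or untested is meant among the compounds shown, and "the series" means these compounds.

In an in vivo ADME assay on the whole organism for pharmacokinetics, with Canis familiaris (Canis lupus familiaris) as the target (a higher number here means that more of the compound sits outside the plasma, a lower number that more of the compound stays in the plasma), two compounds built on a shared core have been measured so far. Compound 1 (`Nc1noc2ccc(-n3nc(C(F)(F)F)c4c3C(=O)N(c3ccc(-c5ccccc5CN5CCC(O)CC5)cc3)CC4)cc12`) gives 1.4 L/kg, and compound 2 (`CNCc1ccccc1-c1ccc(N2CCc3c(C(F)(F)F)nn(-c4ccc5onc(N)c5c4)c3C2=O)cc1`) gives 9.7 L/kg, the higher of the two numbers. Compound 3 (`CN(C)Cc1ccccc1-c1ccc(N2CCc3c(C(F)(F)F)nn(-c4ccc5onc(N)c5c4)c3C2=O)cc1`) is still unmeasured and differs from compound 2 in one place: methyl in place of hydrogen on an amine nitrogen. A methyl replaces a hydrogen on an amine nitrogen, turning methylamino into dimethylamino. Among the measured compounds shown here, only one measured step bears on this change, because it alters the same amine: a 6.9-fold higher number from compound 1 to compound 2 (0.84 log units; beyond the scatter). That step lies beyond the scatter, but it exchanged a whole 4-hydroxypiperidin-1-yl group for methylamino, whereas here only one methyl is added. A much smaller step in this assay is therefore expected, slightly downward if anything and probably within the scatter. The expected step is a 1.3-fold lower number from compound 2 to compound 3 (0.11 log units; within the scatter). For compound 3 the estimated value is 7.5 L/kg, with an expected range of 3.8 L/kg to 14 L/kg.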

Compound 3, volume of distribution at steady state: 4.5 L/kg
Estimate against measurement, compound 3: 1.7-fold (0.22 log units) above, and the stated range covers the measured number.
By their numbers in this assay, from the lowest: compound 1; then compound 3; then compound 2.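

Even a single methyl on this amine nitrogen is enough to matter in this assay, since the change gives a 2.2-fold lower number from compound 2 to compound 3 (0.33 log units; beyond the scatter) and so lies beyond the scatter. Dimethylamino in place of 4-hydroxypiperidin-1-yl gives a 3.2-fold higher number from compound 1 to compound 3 (0.51 log units; beyond the scatter) on the same saturated chain carbon, so all three amines shown can be told apart in this read-out, with compound 3 falling between compound 1 and compound 2. Nothing measured here explains why the number moves with the amine.

As far as these compounds go, three amines are too few to show a rule, so it remains open where an unsubstituted amino group or a pyrrolidin-1-yl group on the same carbon would fall. Also open, from the compounds shown here alone, is whether an ethyl on the nitrogen would change the number as the methyl does.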